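Cytotoxicity notes: pentyl to methoxy on the aryl substituent

A few compounds are considered here, and "the series" means these few. Any claim that something is new, unique, unknown or untested is made for them only; others in the source may bear on it.

Measured compounds in an ADME assay on Vero cells (Chlorocebus sabaeus) for cytotoxicity, read by microscopy, with a stated time of 96 h; a lower number here means that less compound is tolerated, a higher number that more compound is tolerated:
- compound 1 `CN1OC(n2cc3ccoc3nc2=O)CC1CO` gives > 500000 nM.
- compound 2 `CCCc1cc2cn(C3CC(CO)N(C)O3)c(=O)nc2o1` gives > 500000 nM.
- compound 3 `CCCCCc1ccc(-c2cc3cn(C4CC(CO)N(C)O4)c(=O)nc3o2)cc1` gives 6000 nM.

Compound 1 gives a value, > 500000 nM, that is a limit of this assay, not a number. Compound 2 gives a value, > 500000 nM, that is likewise a limit. Going by the values given here, compound 3 is the only compound with a measured number, 6000 nM, and it therefore stands alone as the single fixed point of the series; the other two sit at the limit of > 500000 nM in this assay, at which 2 of the 3 values shown sit.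

Among the compounds with values here, the one step between measured compounds, a step that the two limits leave unreadable from compound 1 to compound 2, cannot be sized because both of its ends are limits, so it gives no guidance on any further change.

Compound 4 `COc1ccc(-c2cc3cn(C4CC(CO)N(C)O4)c(=O)nc3o2)cc1` differs from compound 3 by methoxy in place of pentyl on an aromatic carbon. Within the data shown here, no measured step bears on this change, and nothing here tells how a shorter, oxygen-bearing group at that position affects tolerance in this assay. The expectation for compound 4 is therefore wide, centred on a modest rise: the step of a 6.7-fold higher number from compound 3 to compound 4 (0.82 log units; beyond the scatter) is estimated, and compound 4 is expected to give about 40000 nM, between 6000 nM and 500000 nM.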

Compound 4, minimum cytotoxic concentration: 62500 nM
Compound 4: middle estimate off by 1.6-fold (0.19 log units), on the low side; low and high end bracket the measured number.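

At the place on an aromatic carbon of a six-membered aromatic ring of carbon only, para to a large group, the substituent strongly shifts tolerance in this assay: methoxy in place of pentyl gives a 10-fold higher number from compound 3 to compound 4 (1.02 log units; beyond the scatter). Even with methoxy, the aryl group leaves less compound tolerated than the smaller groups do: 4-methoxyphenyl in place of propyl gives an at least 8.0-fold lower number from compound 2 to compound 4 (0.90 log units; beyond the scatter), and 4-methoxyphenyl in place of hydrogen gives an at least 8.0-fold lower number from compound 1 to compound 4 (0.90 log units; beyond the scatter). These last two steps are bounds rather than sizes, because each starts from a limit of the assay: the limit of > 500000 nM in this assay, at which 2 of the 4 values shown sit.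

The change from pentyl to methoxy alters chain size and introduces oxygen at once, and the compounds shown do not separate the two. From the compounds shown here alone, how an ethoxy group, an amine or a carboxylic acid at this place would behave remains open.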